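The compounds below may be only part of what the source reports. "The series", "measured", "known", "first", "only" and "open" are said of these compounds alone.

Of the compounds shown here, three with a shared core have been tested in a functional assay on MT4 cells (Homo sapiens) for cytotoxicity; a lower number here means a stronger inhibitor, a higher number a weaker inhibitor. For compound 1 (`N#Cc1c(N)cccc1S(=O)(=O)c1ccccc1`), which carries only hydrogen at the varied place, the assay gives a limit, > 5000 nM. For compound 2 (`Cc1ccccc1S(=O)(=O)c1cccc(N)c1C#N`), with methyl, the result is also a limit, > 200000 nM. Within the data shown here, compound 3 (`N#Cc1c(N)cccc1S(=O)(=O)c1ccccc1Br`), with bromo, stands alone as the only one with an actual number, 40000 nM.

Compound 4 (`N#Cc1c(N)cccc1S(=O)(=O)c1ccccc1F`) has fluoro in place of bromo on an aromatic carbon, ortho to a large group: fluoro in place of bromo on an aromatic carbon. Among the measured compounds shown here, no measured step makes this exact swap, so the evidence is indirect. Replacing hydrogen with bromo is a step that the limit leaves unreadable from compound 1 to compound 3, and replacing hydrogen with methyl is a step that the two limits leave unreadable from compound 1 to compound 2, so neither gives a size to build on. For the measured compounds named here, the one readable step, bromo in place of methyl, is an at least 5.0-fold lower number from compound 2 to compound 3 (0.69 log units; beyond the scatter), which shows that a single swap here can matter in this assay. It says nothing about the direction for fluoro, however, so only a small change is expected, with no clear shift beyond the scatter. The expected move is a 1.5-fold higher number from compound 3 to compound 4 (0.18 log units; within the scatter). For compound 4 the estimated value is 60000 nM, with an expected range from 15000 nM to 200000 nM.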

Compound 4, half-maximal inhibitory concentration: 57000 nM
For compound 4 the middle estimate is 1.1-fold (0.02 log units) above the measured one, and the stated range covers the measured number.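

In this assay, fluoro and bromo cannot be told apart at this place on the ring, ortho to a large group: a 1.4-fold higher number from compound 3 to compound 4 (0.15 log units; within the scatter). The methyl compound, by contrast, is separated from fluoro as well as from bromo, with an at least 3.5-fold lower number from compound 2 to compound 4 (0.54 log units; beyond the scatter), so the gap seen earlier is not tied to bromo alone but holds for both halogens shown. The steps from the hydrogen compound to the others cannot be read, because compound 1 gives only a limit and no number to measure from: the limit of > 5000 nM in this assay, at which 1 of the 4 values shown sits.

As far as these compounds go, it therefore stays open whether putting either halogen in place of hydrogen raises or lowers the number, and how far the methyl compound really lies from the rest. Also open, from the compounds shown here alone, is how other groups at this place would read, for example chloro, which would show whether the match between fluoro and bromo extends to a third halogen, or methoxy and an amine, which would test groups that are not halogens.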